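Bromo to fluoro exchange: working notes on compound 3

The compounds below may be only part of what the source reports. "The series", "measured", "known", "first", "only" and "open" are said of these compounds alone.

In a functional assay on NALM-6 cells (Homo sapiens) for cytotoxicity, read by luminescence and CellTiter-Glo, with a stated time of 3 days (a higher number here means a weaker inhibitor, a lower number a stronger inhibitor), compound 2 (`O=C(Nc1ccc(C(F)(F)F)cc1)c1ccc(Br)cc1O`) gives 690 nM and compound 1 (`O=C(Nc1ccc(C(F)(F)F)cc1)c1cc(Br)c(F)cc1O`) gives 1300 nM. These two values lie within the scatter of each other, so no order between compound 2 and compound 1 can be read from the numbers available. Compound 3 (`O=C(Nc1ccc(C(F)(F)F)cc1)c1ccc(F)cc1O`) differs from compound 2 by a single exchange: fluoro in place of bromo on an aromatic carbon. Among the compounds with values here, no measured pair isolates this exchange, so the expectation rests on thin data. A modest shift in this assay toward a higher number, a weaker inhibitor, is expected, slightly beyond the scatter. The expected change is a 2.9-fold higher number from compound 2 to compound 3 (0.46 log units; beyond the scatter). For compound 3 the estimated value is 2000 nM, with an expected range from 800 nM to 6000 nM.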

Compound 3, half-maximal inhibitory concentration: 1530 nM
Beside the measured number, compound 3's estimate is 1.3-fold (0.12 log units) above it; measured number inside the range.
By their numbers in this assay, from the lowest: compounds 2, 1 and 3 (each within the scatter of the next, the first and the last beyond it).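

In this assay, within the data shown here, fluoro in place of bromo on this aromatic carbon, para to a large group and meta to a hydroxy group, gives a 2.2-fold higher number from compound 2 to compound 3 (0.35 log units; beyond the scatter), the first step that lies beyond the scatter, though it is modest. With fluoro held at this place, hydrogen in place of the other bromo gives a 1.2-fold higher number from compound 1 to compound 3 (0.07 log units; within the scatter), which stays within the scatter, so that bromo has no readable effect on the number here. No measurement available bears on why the exchange at this place gives a step of this size.

The compounds shown leave open how chloro, methyl or an amine on this carbon would compare with bromo and fluoro. As far as these compounds go, the hydroxy group and the trifluoromethyl group stay constant throughout, so their contribution also remains open.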